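Dimethoxyphenyl Ketone Variant of a Pyridyl Chalcone

The source may hold more compounds than are shown below. What is called first, only, known or untested is meant among the compounds shown, and "the series" means these compounds.

compound 2, `O=C(/C=C/c1cn(-c2ccccc2)nc1-c1ccncc1)c1ccccc1`: 3400 nM
compound 1, `COc1ccc(C(=O)/C=C/c2cn(-c3ccccc3)nc2-c2ccsc2)c(OC)c1`: 9000 nM

In a functional assay on MCF7 cells (Homo sapiens) for inhibition, read by sulforhodamine B assay, with a stated time of 72 h (on this read-out higher numbers stand for weaker inhibition and lower numbers for stronger inhibition), compound 2 holds the lower of the two numbers, and the gap to compound 1 lies beyond the scatter. Compound 3 `COc1ccc(C(=O)/C=C/c2cn(-c3ccccc3)nc2-c2ccncc2)c(OC)c1` differs from compound 2 by 2,4-dimethoxyphenyl in place of phenyl on a carbonyl carbon. Within the data shown here, no measured pair isolates this change; compound 1 carries the same 2,4-dimethoxyphenyl group yet also differs elsewhere, so its value cannot stand for this change alone. A modest move toward weaker inhibition is nonetheless expected, and the expected step is a 1.6-fold higher number from compound 2 to compound 3 (0.21 log units; within the scatter). The estimate for compound 3 is 5500 nM, within 1700 nM to 18000 nM.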

Compound 3, half-maximal inhibitory concentration: 8800 nM
Beside the measured number, compound 3's estimate is 1.6-fold (0.20 log units) below it, within the range that was stated.
By their numbers in this assay, from the lowest: compound 2; then compounds 3 and 1 (each within the scatter of the next).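

In this assay, 2,4-dimethoxyphenyl in place of phenyl on a carbonyl carbon can now be read alone, with pyridin-4-yl held fixed: a 2.6-fold higher number from compound 2 to compound 3 (0.41 log units; beyond the scatter). Pyridin-4-yl in place of thiophen-3-yl on an aromatic carbon, with 2,4-dimethoxyphenyl held fixed, gives a 1.0-fold lower number from compound 1 to compound 3 (0.01 log units; within the scatter), so these two groups cannot be told apart on this background. No measurement shown here explains either step. On these data alone, whether a methoxy, hydroxyl or fluoro group on the phenyl would move the number as well remains open, and so does how thiophen-3-yl behaves alongside the unsubstituted phenyl.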